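Compound 3 and a pyridin-3-yl swap

This account rests on a few compounds, and the source may have more. Where it says the series, first, only, none or still open, it means among the compounds named here.

In an ADME assay (liver) for metabolic stability, with Liver microsome (Rattus norvegicus) as the target, using microsomes (on this read-out lower numbers stand for slow clearance and higher numbers for fast clearance), three compounds have been measured:
- compound 1 `Nc1nc2c(s1)CCC[C@H]2C(=O)Nc1ccc(C[C@@H]2CC[C@H]([C@H](O)c3ccccc3)N2)cc1`: 63 mL/min/kg
- compound 2 `Nc1nc2c(s1)CC[C@H]2C(=O)Nc1ccc(C[C@@H]2CC[C@H]([C@H](O)c3cccnc3)N2)cc1`: 57 mL/min/kg
- compound 3 `Cc1nc2c(s1)CC[C@H]2C(=O)Nc1ccc(C[C@@H]2CC[C@H]([C@H](O)c3ccccc3)N2)cc1`: 135 mL/min/kg

Compound 3 has the highest number of the three, and its distance to each of the others lies beyond the scatter. The next structure is compound 4 `Cc1nc2c(s1)CC[C@H]2C(=O)Nc1ccc(C[C@@H]2CC[C@H]([C@H](O)c3cccnc3)N2)cc1`. It differs from compound 3 by one change: pyridin-3-yl in place of phenyl on a saturated chain carbon bound to an oxygen on a saturated carbon and a saturated ring carbon.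

For the measured compounds named here, no measured step isolates this swap. Going by the values given here, the one measured single-place step, a 2.1-fold higher number from compound 1 to compound 3 (0.33 log units; beyond the scatter), is a modest one on a carbonyl carbon, and phenyl stays in place across it. Among the compounds with values here, the only other evidence is compound 2, which carries pyridin-3-yl and reads 57 mL/min/kg, but it also differs from compound 3 elsewhere, so its number cannot be credited to the swap alone. That value gives only a weak hint towards a lower number in this assay, and a small move is therefore expected. The expected change is a 1.4-fold lower number from compound 3 to compound 4 (0.13 log units; within the scatter), which is not a step clearly beyond the scatter. For compound 4 the estimated value is 100 mL/min/kg, with an expected range from 55 mL/min/kg to 175 mL/min/kg.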

Compound 4, clearance: 62 mL/min/kg
Compound 4: middle estimate off by 1.6-fold (0.21 log units), on the high side; measured number inside the range.
By their numbers in this assay, from the lowest: compounds 2, 4 and 1 (each within the scatter of the next); then compound 3.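

In this assay this position now has a step of its own: pyridin-3-yl in place of phenyl on a saturated chain carbon bound to an oxygen on a saturated carbon and a saturated ring carbon gives a 2.2-fold lower number from compound 3 to compound 4 (0.34 log units; beyond the scatter) with the methyl group held constant, so this one change is enough to move the read-out beyond the scatter. With pyridin-3-yl held constant, methyl in place of amino on an aromatic carbon gives a 1.1-fold higher number from compound 2 to compound 4 (0.04 log units; within the scatter) and so stays within the scatter, which means that in this pair the methyl group brings no clear move in the number. Nothing at hand explains either of these results.

From the compounds shown here alone, it remains open whether methyl in place of amino would also stay within the scatter with phenyl on that carbon, since this pair speaks only for pyridin-3-yl. Going by these compounds, it is equally open how pyridin-4-yl or pyrimidin-5-yl at the same place would read, so a single ring swap cannot yet show how far this result extends to other rings.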